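Shortening the amine substituent on a fused thiadiazole core

The source may report more compounds than this note shows. Statements on the series, on what has been measured and on what is new or still open speak of the compounds shown alone.

Measured compounds:
Compound 1, `CCCCCNc1nn2c(=O)cc(C(F)(F)F)nc2s1`, 610 nM in an assay on cells for inhibition of alkaline phosphatase, tissue-nonspecific isozyme (Homo sapiens), read by luminescence, with stated times of 7 min and 20 min; a higher number here means a weaker inhibitor, a lower number a stronger inhibitor.
Compound 2, `CN(C)CCNc1nn2c(=O)cc(C(F)(F)F)nc2s1`, 450 nM in this assay.

Among the measured compounds shown here, compound 2 gives the lower of the two numbers measured so far, but the only measured step, a 1.4-fold lower number from compound 1 to compound 2 (0.13 log units; within the scatter), is within the scatter, so compound 2 cannot be called the stronger inhibitor of the pair. Compound 3, `CN(N)c1nn2c(=O)cc(C(F)(F)F)nc2s1`, is not yet measured in this assay. It differs from compound 2 in one place: amino(methyl)amino in place of (2-(dimethylamino)ethyl)amino on an aromatic carbon. For the measured compounds named here, no measured step matches this change. Going by the values given here, the one step available, a 1.4-fold lower number from compound 1 to compound 2 (0.13 log units; within the scatter), exchanged groups at the far end of the same chain and gave no movement beyond the scatter; it says nothing about removing most of that chain. The expectation for compound 3 is therefore wide: the number is estimated at 900 nM, between 250 nM and 3500 nM, which as a step means a 2.0-fold higher number from compound 2 to compound 3 (0.30 log units; within the scatter), with no clear direction beyond the scatter.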

Compound 3, half-maximal inhibitory concentration: 2020 nM
Estimate against measurement, compound 3: 2.2-fold (0.35 log units) below, and the stated range covers the measured number.
By their numbers in this assay, from the lowest: compounds 2 and 1 (each within the scatter of the next); then compound 3.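

Changing the substituent on the aromatic carbon itself moves the number in this assay: amino(methyl)amino in place of (2-(dimethylamino)ethyl)amino gives a 4.5-fold higher number from compound 2 to compound 3 (0.65 log units; beyond the scatter) and amino(methyl)amino in place of pentylamino gives a 3.3-fold higher number from compound 1 to compound 3 (0.52 log units; beyond the scatter) in the same direction. Among the compounds shown here, the earlier pair showed only that exchanging groups at the far end of the chain stayed within the scatter, whereas these two steps show that this position does respond when the longer chain gives way to the much shorter group. No measurement in hand explains why the number rises with this change.

On these data alone, whether the rise goes with the shorter length as such or with the amino(methyl)amino group itself stays open, and a plain short amine such as methylamino or ethylamino on the same aromatic carbon would separate the two. As far as these compounds go, how a cyclic amine such as morpholine or piperidine would read at this place also remains unknown.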